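The compounds below may be only part of what the source reports. "The series", "measured", "known", "first", "only" and "open" are said of these compounds alone.

Going by the values given here, compound 2 `CCN(C)C(=O)N1CCN(C(=S)SCc2cn(Cc3ccc(F)cc3)nn2)CC1` gives 1550 nM in a functional assay on MGC-803 cells (Homo sapiens) for cytotoxicity, read by MTT assay, with a stated time of 72 h (on this read-out higher numbers stand for weaker inhibition and lower numbers for stronger inhibition), the lower of the two numbers measured so far. Among the compounds with values here, compound 1 `NC(=O)N1CCN(C(=S)SCc2cn(Cc3ccc(F)cc3)nn2)CC1` gives 9330 nM in this assay, and the only step measured, a 6.0-fold lower number from compound 1 to compound 2 (0.78 log units; beyond the scatter), concerns the group on the carbonyl carbon. Compound 3 `CCN(C)C(=O)N1CCN(C(=S)SCc2cn(Cc3ccc(OC)cc3)nn2)CC1` differs from compound 2 elsewhere: methoxy in place of fluoro on an aromatic carbon. Within the data shown here, no measured step touches that aromatic position, so the data give no direction for it. A step within the usual scatter is therefore expected, a 1.2-fold higher number from compound 2 to compound 3 (0.06 log units; within the scatter), and compound 3 is estimated at 1800 nM, in a range from 600 nM to 6000 nM.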

Compound 3, half-maximal inhibitory concentration: 87900 nM
The estimate for compound 3 lay 49-fold (1.69 log units) below the measured number; the whole stated range lies below it.
By their numbers in this assay, from the lowest: compound 2; then compound 1; then compound 3.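

Going by these compounds alone, this aromatic position is not a silent one: methoxy in place of fluoro gives the largest change seen so far (a 57-fold higher number from compound 2 to compound 3 (1.75 log units; beyond the scatter)), well beyond the only earlier step (a 6.0-fold lower number from compound 1 to compound 2 (0.78 log units; beyond the scatter)). A small swap on the ring can therefore matter more than the change on the carbonyl carbon. Nothing in the data at hand explains this loss.

As far as these compounds go, whether other groups here, such as a chlorine atom, a hydroxyl or an amine, would stay close to fluoro or fall towards methoxy remains open. Also open, from the compounds shown here alone, is whether the same swap would have a similar effect in compound 1.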